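The compounds below may be only part of what the source reports. "The series", "measured", "known", "first", "only" and "open" are said of these compounds alone.

Measured so far in a functional assay on DLD-1 cells (Homo sapiens) for antiproliferative activity, read by CellTiter-Glo, with a stated time of 72 h; a lower number here means a stronger inhibitor, a higher number a weaker inhibitor:
Compound 1 `Cc1noc(C)c1S(=O)(=O)N1CCC(N2CCC(C)CC2)CC1` gives > 5000 nM.
Compound 2 `Cc1ccc(-c2cccc(S(=O)(=O)N3CCC(N4CCC(C)CC4)CC3)c2)cc1` gives 11 nM.
Compound 3 `COc1cc(C)c(S(=O)(=O)N2CCC(N3CCC(C)CC3)CC2)cc1C(C)C` gives 3 nM.

The reading for compound 1 is a limit of the assay, not a number: compound 1 sits at the limit of > 5000 nM in this assay, at which 1 of the 3 values shown sits, the weakest reading of the three. Compound 2 and compound 3 each carry a six-membered aromatic ring of carbon only on the sulfonyl sulfur, and both give numbers far beneath that limit, the gap between the two lying within the usual scatter. Compound 4 `CC1CCN(C2CCN(S(=O)(=O)c3ccccc3Br)CC2)CC1` carries 2-bromophenyl in place of 3,5-dimethyl-1,2-oxazol-4-yl on a sulfonyl sulfur. Within the data shown here, no measured pair differs in this one place alone, so the size of the step is untested. Still, as compound 2 gives 11 nM and compound 3 gives 3 nM, the step of an at least 25-fold lower number from compound 1 to compound 4 (1.39 log units; beyond the scatter) is expected to be a large gain, well beyond the scatter. For compound 4 the estimate is 200 nM, with a range from 40 nM to 1500 nM.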

Compound 4, half-maximal inhibitory concentration: 3 nM
Beside the measured number, compound 4's estimate is 67-fold (1.82 log units) above it; the whole stated range lies above it.
By their numbers in this assay, from the lowest: compounds 3 and 4 (each within the scatter of the next); then compound 2. At a limit, above all of these: compound 1.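

In this assay, 2-bromophenyl in place of 3,5-dimethyl-1,2-oxazol-4-yl on a sulfonyl sulfur gives an at least 1600-fold lower number from compound 1 to compound 4 (3.22 log units; beyond the scatter). Among these compounds, this is the first change at this position that can be read with the rest of the compound held the same, but its full size stays unknown, as the reading for compound 1 is a limit of the assay: the limit of > 5000 nM in this assay, at which 1 of the 4 values shown sits. Both groups hold 7 heavy atoms, so this large step comes with no change in that count.

On these data alone, whether the bromine itself matters remains open, and a plain phenyl or a chlorophenyl on the same sulfur would test that.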